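This account rests on a few compounds, and the source may have more. Where it says the series, first, only, none or still open, it means among the compounds named here.

In a functional assay on HeLa cells (Homo sapiens) for inhibition, read by MTT assay, with a stated time of 48 h (on this read-out lower numbers stand for stronger inhibition of growth and higher numbers for weaker inhibition of growth), compound 1 `Cn1cc(C2CC(c3ccccc3)=NN2C(=O)c2cccnc2)c2ccccc21` reads > 10000 nM and this is a limit of the assay, not a number. Among the compounds with values here, compound 2 `COc1ccc2c(c1)c(C1CC(c3ccccc3)=NN1C(=O)c1cccnc1)cn2C` gives 3590 nM as the only true number so far. Compound 3 `COc1cccc(C2=NN(C(=O)c3cccnc3)C(c3cn(C)c4ccc(OC)cc34)C2)c1` differs from compound 2 by methoxy in place of hydrogen on an aromatic carbon in the change phenyl to 3-methoxyphenyl. Within the data shown here, one measured step bears on this: the same exchange on another ring gave an at least 2.7-fold lower number from compound 1 to compound 2 (0.44 log units; beyond the scatter) as its result. A modest move to a lower number is therefore expected, with little certainty from one step at a different site. The expected step is a 1.8-fold lower number from compound 2 to compound 3 (0.25 log units; within the scatter) on this estimate. Compound 3 is estimated at 2000 nM within a range of 500 nM to 8000 nM as its expected span.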

Compound 3, concentration for 50% growth inhibition: 1270 nM
For compound 3 the middle estimate is 1.6-fold (0.20 log units) above the measured one, and the stated range covers the measured number.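

In this assay, within the data shown here, the change from phenyl to 3-methoxyphenyl gives a 2.8-fold lower number from compound 2 to compound 3 (0.45 log units; beyond the scatter), the first step with a true number at both ends. Methoxy in place of hydrogen thus lowers the number on this ring as well, in a compound already carrying methoxy on another ring. The earlier step starts from compound 1, whose reading is a limit and not a number: the limit of > 10000 nM in this assay, at which 1 of the 3 values shown sits.

Open, going by these compounds, is whether an amine, a fluorine or a longer alkoxy chain at this position reads like methoxy. Also open, on these data alone, is whether the step holds without the methoxy already present in compound 2.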